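Aryl for Alkyl on the Aminopyrimidine Nitrogen

The source may report more compounds than this note shows. Statements on the series, on what has been measured and on what is new or still open speak of the compounds shown alone.

Compound 1, `O=C(Nc1ccc(Nc2nccc(NC3CCCC3)n2)cc1)Nc1ccc(Cl)c(C(F)(F)F)c1`: 2510 nM
Compound 2, `CCCNc1ccnc(Nc2ccc(NC(=O)Nc3ccc(Cl)c(C(F)(F)F)c3)cc2)n1`: 4240 nM

Among the compounds with values here, in a functional assay on HCT-116 cells (Homo sapiens) for antiproliferative activity, read by MTT assay, with a stated time of 72 h (a lower number here means a stronger inhibitor, a higher number a weaker inhibitor), compound 2 gives 4240 nM, the higher of the two numbers measured so far. Compound 1 gives 2510 nM. Within the data shown here, the single measured step, a 1.7-fold higher number from compound 1 to compound 2 (0.23 log units; within the scatter), lies within the scatter, so the two compounds cannot be ordered on these numbers. Compound 3, `O=C(Nc1ccc(Nc2nccc(Nc3cccc(Cl)c3)n2)cc1)Nc1ccc(Cl)c(C(F)(F)F)c1`, differs from compound 2 in one place: 3-chlorophenyl in place of propyl on a nitrogen on an aromatic ring. Among the measured compounds shown here, the only step available swaps one alkyl group for another on this same nitrogen and was small; no measured step puts an aromatic ring there, so it bears on the present change only loosely and gives no direction. The step from compound 2 to compound 3 is therefore expected to be a 2.1-fold lower number from compound 2 to compound 3 (0.33 log units; beyond the scatter), with wide uncertainty. Compound 3 is estimated at 2000 nM, within a range from 500 nM to 8000 nM.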

Compound 3, half-maximal inhibitory concentration: 4820 nM
For compound 3 the middle estimate is 2.4-fold (0.38 log units) below the measured one; measured number inside the range.
By their numbers in this assay, from the lowest: compounds 1, 2 and 3 (each within the scatter of the next).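

In this assay, an aromatic ring on this nitrogen produces no readable shift: 3-chlorophenyl in place of propyl gives (a 1.1-fold higher number from compound 2 to compound 3 (0.06 log units; within the scatter)), and 3-chlorophenyl in place of cyclopentyl gives (a 1.9-fold higher number from compound 1 to compound 3 (0.28 log units; within the scatter)). Within the data shown here, the earlier compounds compared only two alkyl groups here, whereas these steps show that propyl, cyclopentyl and 3-chlorophenyl cannot be separated on these numbers, even though the entering group has 7 heavy atoms against the 3 of propyl. Nothing available accounts for this result.

As far as these compounds go, it remains open whether any group on this nitrogen can move the number clearly, for example a chain ending in an amine or a carboxylic acid. A plain phenyl group would also be needed to show whether the chlorine of 3-chlorophenyl matters.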